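Swapping methyl for methoxy on a potent compound

The source may hold more compounds than are shown below. What is called first, only, known or untested is meant among the compounds shown, and "the series" means these compounds.

Values measured in a functional assay on MCF7 cells (Homo sapiens) for cytotoxicity, read by CellTiter-Glo, with a stated time of 5 days (on this read-out lower numbers stand for stronger inhibition and higher numbers for weaker inhibition), so far:
- compound 1 `CC/C(=C(/c1ccc(/C=C/C(=O)O)cc1)c1ccc2[nH]ncc2c1)c1ccc(Cl)cc1` with 15 nM
- compound 2 `CC/C(=C(/c1ccc(/C=C/C(=O)O)cc1)c1ccc2[nH]ncc2c1)c1ccccc1C` with 4 nM

Among the compounds with values here, with only two numbers to compare, compound 2 has the lower one, and lower means stronger inhibition here. Within the data shown here, the single measured step is a 3.8-fold lower number from compound 1 to compound 2 (0.57 log units; beyond the scatter) and it lies beyond the scatter. It changed the same aromatic ring that changes next, so it shows that this ring can move the number, though only modestly.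

Compound 3 `CC/C(=C(/c1ccc(/C=C/C(=O)O)cc1)c1ccc2[nH]ncc2c1)c1ccccc1OC` has methoxy in place of methyl on an aromatic carbon, ortho to a large group, which reads as 2-methylphenyl to 2-methoxyphenyl: methoxy in place of methyl on an aromatic carbon is the whole change. Among the measured compounds shown here, no measured step swaps these two groups, so the data give no firm direction. The group that leaves is small and the group that enters is only slightly larger, so a shift smaller than the one measured seems likely. The expected step is a 1.5-fold higher number from compound 2 to compound 3 (0.18 log units; within the scatter) as an estimate, with nothing beyond the scatter expected. The estimated value for compound 3 is 6 nM in this assay with an expected range from 2 nM to 18 nM as its likely span.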

Compound 3, half-maximal inhibitory concentration: 25 nM
The estimate for compound 3 lay 4.2-fold (0.62 log units) below the measured number; measured number above the stated range.
By their numbers in this assay, from the lowest: compound 2; then compounds 1 and 3 (each within the scatter of the next).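

In this assay, the step of a 6.3-fold higher number from compound 2 to compound 3 (0.80 log units; beyond the scatter) shows that this aromatic carbon responds even to a swap between two small groups, so the earlier gain on this ring does not come with just any small group placed ortho to a large group. Compound 2 holds its low number with methyl, while the methoxy of compound 3 gives that advantage up. The step of a 1.7-fold higher number from compound 1 to compound 3 (0.22 log units; within the scatter) lies within the scatter, so 2-methoxyphenyl and 4-chlorophenyl cannot be told apart here, and among these three compounds only 2-methylphenyl stands out.

As far as these compounds go, whether a longer chain such as ethyl, or a hydroxyl or an amine on the same aromatic carbon, would give a number close to that of compound 2 or close to that of compound 3 remains open. No measurement is available that explains why methyl and methoxy differ at this place.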